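The source may hold more compounds than are shown below. What is called first, only, known or untested is meant among the compounds shown, and "the series" means these compounds.

In a functional assay on A2780 cells (Homo sapiens) for antiproliferative activity, read by fluorescence, with a stated time of 72 h (on this read-out higher numbers stand for weaker inhibition and lower numbers for stronger inhibition), three amides on a shared core have been measured. Compound 1 (`CN1CCC(C(=O)N2Cc3c(NC(=O)C4CC4)n[nH]c3C2(C)C)CC1`) gives 1420 nM and compound 2 (`CN1CCC(C(=O)N2Cc3c(NC(=O)c4ccc5ccccc5c4)n[nH]c3C2(C)C)CC1`) gives 270 nM, while compound 3 (`CN1CCC(C(=O)N2Cc3c(NC(=O)c4cccs4)n[nH]c3C2(C)C)CC1`) gives 30 nM as the lowest of the three numbers, beyond the scatter of both others. Compound 4 (`CN1CCC(C(=O)N2Cc3c(NC(=O)c4ccc(C(F)(F)F)cc4)n[nH]c3C2(C)C)CC1`) is still unmeasured and carries 4-(trifluoromethyl)phenyl in place of thiophen-2-yl on a carbonyl carbon. All three measured steps change this same place. Among the compounds with values here, the step of a 5.3-fold lower number from compound 1 to compound 2 (0.72 log units; beyond the scatter) is modest, the step of a 47-fold lower number from compound 1 to compound 3 (1.68 log units; beyond the scatter) is large, and the step of a 9.0-fold lower number from compound 2 to compound 3 (0.95 log units; beyond the scatter) is modest, so thiophen-2-yl has the lowest number so far. Within the data shown here, compound 2, with 270 nM in this assay, is the closest precedent for an aromatic ring of carbon only, although no substituted phenyl has been measured. A modest move to a higher number, meaning weaker inhibition, is therefore expected. The expected change is a 4.0-fold higher number from compound 3 to compound 4 (0.60 log units; beyond the scatter) and would lie beyond the scatter. The estimate for compound 4 is 120 nM, with an expected range from 35 nM to 450 nM in this assay.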

Compound 4, half-maximal inhibitory concentration: 60 nM
Beside the measured number, compound 4's estimate is 2.0-fold (0.30 log units) above it; the measured number falls inside the stated range.
By their numbers in this assay, from the lowest: compounds 3 and 4 (each within the scatter of the next); then compound 2; then compound 1.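

In this assay, 4-(trifluoromethyl)phenyl on the carbonyl carbon gives a 2.0-fold higher number from compound 3 to compound 4 (0.30 log units; within the scatter), so a six-membered aromatic ring of carbon only can stand level with thiophen-2-yl, and a hetero atom in the ring is not needed to reach this range. The same group also gives a 4.5-fold lower number from compound 2 to compound 4 (0.65 log units; beyond the scatter) and a 24-fold lower number from compound 1 to compound 4 (1.37 log units; beyond the scatter), so all three aromatic groups give lower numbers than cyclopropyl, while compound 2 shows that an aromatic ring of carbon only does not by itself set the level. Nothing available explains these differences.

Going by these compounds, what a plain phenyl ring would give remains open, and with it how much of the result for compound 4 belongs to the trifluoromethyl group. Also open, on these data alone, is how this position would respond to a pyridine ring, or to an amine or a carboxylic acid on the phenyl ring.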